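Swapping the Aryl Ring on the Amidine Nitrogen

The compounds below may be only part of what the source reports. "The series", "measured", "known", "first", "only" and "open" are said of these compounds alone.

Three compounds share one core and differ only in the aromatic ring attached to an amine nitrogen. Compound 1 `Cc1ccc(S(=O)(=O)/N=C(/CCNC2=CC(=O)c3ccccc3C2=O)Nc2ccccc2[N+](=O)[O-])cc1` carries a 2-nitrophenyl there; in a functional assay on MCF7 cells (Homo sapiens) for cytotoxicity, read by MTT assay, with a stated time of 48 h (on this read-out lower numbers stand for stronger inhibition and higher numbers for weaker inhibition), compound 1 gives 3090 nM, the lowest of the three numbers. Compound 2 `Cc1ccc(S(=O)(=O)/N=C(/CCNC2=CC(=O)c3ccccc3C2=O)Nc2cccc(C(F)(F)F)c2)cc1` bears a 3-(trifluoromethyl)phenyl instead, and compound 2 gives 89100 nM; that exchange reads a 29-fold higher number from compound 1 to compound 2 (1.46 log units; beyond the scatter). Compound 3 `Cc1ccc(S(=O)(=O)/N=C(/CCNC2=CC(=O)c3ccccc3C2=O)Nc2ccc(F)c(F)c2)cc1` bears a 3,4-difluorophenyl, and compound 3 gives 9420 nM, a step of a 3.0-fold higher number from compound 1 to compound 3 (0.48 log units; beyond the scatter). Between the two replacements the step is a 9.5-fold lower number from compound 2 to compound 3 (0.98 log units; beyond the scatter).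

Compound 4 `Cc1ccc(S(=O)(=O)/N=C(/CCNC2=CC(=O)c3ccccc3C2=O)Nc2cc(F)c(F)c(F)c2)cc1` has not yet been measured. It differs from compound 1 in one place: 3,4,5-trifluorophenyl in place of 2-nitrophenyl on an amine nitrogen. Both earlier exchanges of the 2-nitrophenyl raised the number, one modestly and one strongly, so a rise is expected here as well. The 3,4,5-trifluorophenyl most resembles the ring of compound 3, so compound 4 is expected to land near or somewhat above compound 3 because compound 3 gives 9420 nM. The estimate for compound 4 is 12000 nM, with a range from 4000 nM to 40000 nM. The expected step is therefore a 3.9-fold higher number from compound 1 to compound 4 (0.59 log units; beyond the scatter), toward weaker inhibition.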

Compound 4, half-maximal inhibitory concentration: 6610 nM
Compound 4: middle estimate off by 1.8-fold (0.26 log units), on the high side; the measured number falls inside the stated range.
By their numbers in this assay, from the lowest: compound 1; then compounds 4 and 3 (each within the scatter of the next); then compound 2.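

Replacing the 2-nitrophenyl with 3,4,5-trifluorophenyl still gives a 2.1-fold higher number from compound 1 to compound 4 (0.33 log units; beyond the scatter) in this assay, so even this ring with three fluoro groups does not match compound 1. Adding a third fluoro to the ring of compound 3 gives a 1.4-fold lower number from compound 3 to compound 4 (0.15 log units; within the scatter), which means this added fluoro produces no change that can be told apart from ordinary assay variation. The 3-(trifluoromethyl)phenyl stays well apart from the new ring, with a 13-fold lower number from compound 2 to compound 4 (1.13 log units; beyond the scatter), a gap of the same kind already seen with compound 3.

On these data alone, it remains open whether the low number of compound 1 depends on the nitro group itself or on its place on the ring, a question that a 4-nitrophenyl or a 2-fluorophenyl could address. As far as these compounds go, how a ring bearing an amine or a carboxylic acid would behave is also open. Nothing measured here explains these differences.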